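Thiazole Carbonyl Replaces Pyridylmethyl on the Ring Nitrogen

This account rests on a few compounds, and the source may have more. Where it says the series, first, only, none or still open, it means among the compounds named here.

Within the data shown here, compound 3 `CCCCNc1nc(N)nc2c1CN(Cc1ccncc1)CC2` gives 0.29 uM in an assay on HEK293 cells for agonist activity at Toll-like receptor 8 (Homo sapiens), read by a luciferase reporter, with a stated time of 6 h (on this read-out lower numbers stand for an effect already at smaller amounts and higher numbers for an effect only at larger amounts of compound), the highest of the three numbers so far. Compound 1 `CCCCNc1nc(N)nc2c1CN(Cc1cc(F)cc(F)c1)CC2` gives 0.23 uM, and the step of a 1.3-fold higher number from compound 1 to compound 3 (0.10 log units; within the scatter) keeps the two together. Compound 2 `CCCCNc1nc(N)nc2c1CN(Cc1ccc(OC)cc1)CC2` gives 0.08 uM; the step of a 3.6-fold higher number from compound 2 to compound 3 (0.56 log units; beyond the scatter) and the step of a 2.9-fold lower number from compound 1 to compound 2 (0.46 log units; beyond the scatter) set compound 2 apart from the other two.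

Compound 4 `CCCCNc1nc(N)nc2c1CN(C(=O)c1csc(C)n1)CC2` differs from compound 3 in one place: (2-methyl-1,3-thiazol-4-yl)carbonyl in place of (pyridin-4-yl)methyl on an amine nitrogen in a ring. The measured steps all swap one aromatic group for another on the same saturated chain carbon, and none of them alters the link to the ring nitrogen, so they bear on the new change only loosely. What they do show is that exchanging the aromatic group moves the number modestly at most. Among the measured compounds shown here, with no step that changes the link itself, the expectation for compound 4 is a step of a 1.4-fold higher number from compound 3 to compound 4 (0.14 log units; within the scatter) of modest size and uncertain direction. Compound 4 is therefore estimated at 0.4 uM, with a range from 0.1 uM to 2 uM.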

Compound 4, minimum effective concentration: 1.8 uM
The estimate for compound 4 lay 4.5-fold (0.65 log units) below the measured number, and the stated range covers the measured number.
By their numbers in this assay, from the lowest: compound 2; then compounds 1 and 3 (each within the scatter of the next); then compound 4.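

Putting (2-methyl-1,3-thiazol-4-yl)carbonyl on the amine nitrogen in a ring gives a 6.2-fold higher number from compound 3 to compound 4 (0.79 log units; beyond the scatter) in this assay, the largest of the steps shown so far. Among these compounds, it is also the only step in which the saturated chain carbon gives way to a carbonyl, whereas the earlier steps exchanged only the aromatic group on that carbon, so the number at this position can move further than those steps showed. Nothing available here accounts for the rise.

Compound 4 changes the link and the aromatic ring together, so the compounds shown do not separate the contribution of the carbonyl from that of the thiazole. A (pyridin-4-yl)carbonyl or a (2-methyl-1,3-thiazol-4-yl)methyl group on the same nitrogen would each alter only one of the two.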